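Swapping ethylcarbamoyl for acetamidomethyl

The source may hold more compounds than are shown below. What is called first, only, known or untested is meant among the compounds shown, and "the series" means these compounds.

Measured in a functional assay (aorta) with Rattus norvegicus as the target; a lower number here means a stronger inhibitor, a higher number a weaker inhibitor:
- Compound 1 `CCCCOC(=O)CN(c1ccccc1)[C@H]1c2cc(C#N)ccc2OC(C)(C)[C@@H]1O`: 27000 nM
- Compound 2 `CCNC(=O)CN(c1ccccc1)[C@H]1c2cc(C#N)ccc2OC(C)(C)[C@@H]1O`: > 30000 nM, a limit and not a number

Compound 2 gives no exact value and sits at the limit of > 30000 nM in this assay, at which 1 of the 2 values shown sits. Compound 3 `CC(=O)NCCN(c1ccccc1)[C@H]1c2cc(C#N)ccc2OC(C)(C)[C@@H]1O` has the same atoms as compound 2, joined differently. It carries acetamidomethyl in place of ethylcarbamoyl on a saturated chain carbon bound to a nitrogen on an aromatic ring. Cut one bond further out, the same difference reads (ethylcarbamoyl)methyl to 2-acetamidoethyl.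

Within the data shown here, only one measured step bears on this change, with ethylamino in place of butoxy on a carbonyl carbon: an at least 1.1-fold higher number from compound 1 to compound 2 (0.04 log units; that floor lies within the scatter). On these data alone, its true size stays unknown, since compound 2 has only a limit. This is thin evidence, and it does not test the new arrangement directly. Among the measured compounds shown here, with compound 1 at 27000 nM as the only exact number in this assay, no step beyond the scatter is expected, in either direction. The expected change is a step that the limit leaves unreadable from compound 2 to compound 3. A reading that is again only a limit is quite likely. Compound 3 is estimated at 35000 nM, with an expected range of 12000 nM to 100000 nM.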

Compound 3, half-maximal inhibitory concentration: > 30000 nM
Compound 3 gave a limit, no number; the forecaster's own chance of this, stated with the estimate: 65%; the middle value does not contradict the limit.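

In this assay, compound 3 gives > 30000 nM, which is a limit and not a number, so a second arrangement of the same amide atoms on this chain also yields no exact value. The step between compound 2 and compound 3 cannot be read, and the two arrangements cannot be ranked, because both stop at a limit: the limit of > 30000 nM in this assay, at which 2 of the 3 values shown sit.

On these data alone, replacing butoxycarbonyl with acetamidomethyl gives an at least 1.1-fold higher number from compound 1 to compound 3 (0.04 log units; that floor lies within the scatter), and the true size of that step stays unknown.

The compounds shown leave open how far the number for either amide actually lies from that of compound 1, which gives 27000 nM, and whether the ethylcarbamoyl and acetamidomethyl arrangements differ at all. They also leave open whether any group at this place can bring the number clearly lower, such as a carboxylic acid, a primary amine or a longer chain ending in an amide.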